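The source may hold more compounds than are shown below. What is called first, only, known or untested is meant among the compounds shown, and "the series" means these compounds.

Measured compounds:
Compound 1 `CN(C)C(=O)c1cc2cnc(Nc3ccc(N)cn3)nc2n1C1CCCC1`: -21.2%
Compound 2 `CN(C)C(=O)c1cc2cnc(Nc3ccc(NC(=O)C4(C(=O)Nc5ccccc5F)CC4)cc3)nc2n1C1CCCC1`: 63.4%
Compound 3 `Nc1ccc(NC(=O)C2(C(=O)Nc3ccc(F)cc3)CC2)cc1F`: 21.7%

These three compounds were tested in a functional assay on SiHa cells (Homo sapiens) for inhibition, read by CCK-8 assay, with a stated time of 72 h, tested at 1 uM; on this read-out lower numbers stand for less inhibition of growth and higher numbers for more inhibition of growth at the one concentration tested. Compound 2 stands highest of the three at 63.4% and lies beyond the scatter above both others. Compound 3 follows at 21.7%, and compound 1 comes last at -21.2%.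

The next compound to be tested in this assay is compound 4 `CN(C)C(=O)c1cc2cnc(Nc3ccc(NC(=O)C4(C(=O)Nc5cccc(Br)c5)CC4)cc3)nc2n1C1CCCC1`. It keeps the rest of compound 2 and carries 3-bromophenyl in place of 2-fluorophenyl on an amide-type nitrogen. The exchanged group is the same size by heavy-atom count, and the ring stays a six-membered aromatic ring of carbon only. Among the measured compounds shown here, no two measured compounds differ in one place, so the data give no direct measure of such an exchange. The expectation therefore starts from the value of compound 2 at 63.4% and allows for a modest fall. The expected change is a number 8.4 percentage points lower from compound 2 to compound 4 (within the scatter), a step that may well stay within the scatter. For compound 4 the estimated value is 55%, with an expected range from 30% to 76%.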

Compound 4, percent growth inhibition at one concentration: 13.9%
Estimate against measurement, compound 4: 41.1 percentage points above; measured number outside the range, below it.
By their numbers in this assay, from the lowest: compound 1; then compounds 4 and 3 (each within the scatter of the next); then compound 2.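

In this assay, the exchange of 2-fluorophenyl for 3-bromophenyl on the amide-type nitrogen gives a number 49.5 percentage points lower from compound 2 to compound 4 (beyond the scatter), a large step and the only one-place comparison among the compounds shown, so growth inhibition at this position clearly depends on which of these two groups is present. The two groups have the same heavy-atom count, the same six-membered aromatic ring of carbon only, no hydrogen-bond donors or acceptors and no net charge, so these counted features alone do not account for the difference between compound 2 and compound 4. No measurement is available that explains the size of this step.

The exchange replaces fluorine with bromine and 2-fluorophenyl's substitution pattern with that of 3-bromophenyl in a single step, so the compounds shown cannot assign the fall to either part of the change. Going by these compounds, how an unsubstituted phenyl or a methoxyphenyl group on the same nitrogen would compare with compound 2 and compound 4 also remains open.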